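Trifluoromethylphenyl in place of fluorophenyl: compound 3

The compounds below may be only part of what the source reports. "The series", "measured", "known", "first", "only" and "open" are said of these compounds alone.

Compound 1 `COc1cc2c(Oc3ccc(NC(=O)c4cc(-c5ccc(C(F)(F)F)cc5)ccn4)cc3F)ccnc2cc1OCCCN1CCCCC1` gives 230 nM in a functional assay on HT-29 cells (Homo sapiens) for cytotoxicity, read by MTT assay, with a stated time of 72 h; a higher number here means a weaker inhibitor, a lower number a stronger inhibitor. Compound 2 `COc1cc2c(Oc3ccc(NC(=O)c4cc(-c5ccccc5F)ccn4)cc3F)ccnc2cc1OCCCN1CCCC1` gives 230 nM in this assay, level with compound 1 at the digits shown, the two values lying within the scatter. Compound 3 `COc1cc2c(Oc3ccc(NC(=O)c4cc(-c5ccc(C(F)(F)F)cc5)ccn4)cc3F)ccnc2cc1OCCCN1CCCC1` has not yet been measured; it differs from compound 2 by 4-(trifluoromethyl)phenyl in place of 2-fluorophenyl on an aromatic carbon. Among the measured compounds shown here, no measured pair isolates this change. The step of no change at the digits printed from compound 2 to compound 3 (within the scatter) is expected to stay within the scatter, since compound 1, carrying the same 4-(trifluoromethyl)phenyl group, shows 230 nM. Compound 3 is therefore estimated at 230 nM, with a range from 100 nM to 520 nM.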

Compound 3, half-maximal inhibitory concentration: 720 nM
Beside the measured number, compound 3's estimate is 3.1-fold (0.50 log units) below it, and the stated range ends below it.
By their numbers in this assay, from the lowest: compounds 1 and 2 (each within the scatter of the next); then compound 3.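

In this assay, 4-(trifluoromethyl)phenyl in place of 2-fluorophenyl on the aromatic carbon opposite the ring nitrogen gives a 3.1-fold higher number from compound 2 to compound 3 (0.50 log units; beyond the scatter), so this position responds to the change of aryl group. With 4-(trifluoromethyl)phenyl held fixed, pyrrolidin-1-yl in place of piperidin-1-yl on the saturated chain carbon gives a 3.1-fold higher number from compound 1 to compound 3 (0.50 log units; beyond the scatter), so the amine at the end of the chain also counts. Nothing measured here accounts for either step.

Still open, as far as these compounds go, is how piperidin-1-yl behaves alongside 2-fluorophenyl. Also open, from the compounds shown here alone, is whether a morpholine on the same chain, or 4-fluorophenyl on the same aromatic carbon, would follow these steps.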